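This account rests on a few compounds, and the source may have more. Where it says the series, first, only, none or still open, it means among the compounds named here.

Working notes on the series. In a functional assay on MGC-803 cells (Homo sapiens) for inhibition, read by MTT assay, with a stated time of 48 h (on this read-out higher numbers stand for weaker inhibition and lower numbers for stronger inhibition), compound 1 `CCCCC(=O)N(Cc1ccc(OC)c(O)c1)c1cc(OC)c(OC)c(OC)c1` gives 66 nM, the lowest of the two numbers obtained so far. Compound 3 `COc1ccc(CNc2cc(OC)c(OC)c(OC)c2)cc1F` gives 39700 nM in this assay, a gap from compound 1 that lies well beyond the scatter. Compound 2 `COc1cc(NCc2ccc(Br)cc2)cc(OC)c1OC` reaches only the limit of this assay, > 80000 nM, and no number is reported for it (the limit of > 80000 nM in this assay, at which 1 of the 3 values shown sits). Compound 1 is the only one of the three that carries an acyl group on the amide-type nitrogen; compounds 2 and 3 have a bare nitrogen. Within the data shown here, no single-point step between measured compounds exists, so no step size can be assigned to that difference.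

Compound 4 `COc1ccc(CN(C(=O)C(C)C)c2cc(OC)c(OC)c(OC)c2)cc1O` is the next member to be tested. It differs from compound 1 in one place: isopropyl in place of butyl on a carbonyl carbon. The amide is kept, read one bond further out as butylcarbonyl to isopropylcarbonyl, and everything else in the core of compound 1 is unchanged. Among the measured compounds shown here, with no measured step among acylated compounds to draw on, the expected step from compound 1 to compound 4 is set small, a 1.7-fold higher number from compound 1 to compound 4 (0.22 log units; within the scatter), within the usual scatter and leaning toward a slightly higher number. Compound 4 is therefore estimated to give about 110 nM in this assay, with an expected range from 30 nM to 450 nM.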

Compound 4, half-maximal inhibitory concentration: 210 nM
For compound 4 the middle estimate is 1.9-fold (0.28 log units) below the measured one, within the range that was stated.
By their numbers in this assay, from the lowest: compound 1; then compound 4; then compound 3. At a limit, above all of these: compound 2.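

The change from butyl to isopropyl on a carbonyl carbon gives the first step measured among the acylated compounds: in this assay, isopropyl in place of butyl gives a 3.2-fold higher number from compound 1 to compound 4 (0.50 log units; beyond the scatter) and so the step is modest but lies beyond the scatter. Among these compounds, this shows that the assay responds to the group on the carbonyl carbon even when the amide and the rest of the core of compound 1 are unchanged, which the earlier compounds could not show, since none of them formed a single-change pair. Nothing in the data at hand bears on why this step has this size.

Among the compounds shown here, the single pair changes the chain from 4 carbon atoms to 3 and also makes it branched, so it cannot separate the effect of chain length from that of branching; a straight propyl chain would be the direct comparison for both compounds. Going by these compounds, how the series behaves with a longer chain such as hexyl, with a small ring such as cyclopropyl, or with a chain ending in an amine or a carboxylic acid remains open.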